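This account rests on a few compounds, and the source may have more. Where it says the series, first, only, none or still open, it means among the compounds named here.

Measured in a functional assay on MDA-MB-231 cells (Homo sapiens) for cytotoxicity, read by MTT assay, with a stated time of 48 h; on this read-out lower numbers stand for stronger inhibition and higher numbers for weaker inhibition:

- Compound 1 `Fc1ccc(C(CCCCOCc2ccc(Oc3ccc(Cl)cc3)cc2)c2ccc(F)cc2)cc1`: > 20000 nM (a limit)
- Compound 2 `O=C(OCCCC(c1ccc(F)cc1)c1ccc(F)cc1)c1cc(Cl)c(OCc2ccccc2)c(Cl)c1`: > 20000 nM (a limit)
- Compound 3 `Cc1ccc(NC(=O)NCCCCC(c2ccc(F)cc2)c2ccc(F)cc2)cc1`: > 20000 nM (a limit)

All three compounds share one result: the limit of > 20000 nM in this assay, at which 3 of the 3 values shown sit. Compound 3 stands at > 20000 nM, which is a limit and not a number.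

Among the measured compounds shown here, no two measured compounds differ in just one place, so no measured step shows how large a single change can be. Compound 4 `O=C(NCCCCC(c1ccc(F)cc1)c1ccc(F)cc1)Nc1cccc(C(F)(F)F)c1` carries 3-(trifluoromethyl)phenyl in place of 4-methylphenyl on an amide-type nitrogen. With all three relatives at that limit (the limit of > 20000 nM in this assay, at which 3 of the 3 values shown sit), no shift beyond the usual scatter is expected in this assay, and the expected step is a number no higher from compound 3 to compound 4 (the limit leaves the size open). A report of only a limit is also likely. The estimate for compound 4 is 20000 nM, within an expected range of 8000 nM to 40000 nM.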

Compound 4, half-maximal inhibitory concentration: 3380 nM
For compound 4 the middle estimate is 5.9-fold (0.77 log units) above the measured one, outside the stated range (below it).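

In this assay, 3-(trifluoromethyl)phenyl in place of 4-methylphenyl on an amide-type nitrogen gives an at least 5.9-fold lower number from compound 3 to compound 4 (0.77 log units; beyond the scatter), the first measured sign that a change at this place can move the read-out. From the compounds shown here alone, compound 3 is held at a limit, > 20000 nM, so the true size of the step stays open. Compound 4 alone stands clear of the limit shared by the other compounds: the limit of > 20000 nM in this assay, at which 3 of the 4 values shown sit.

This one change alters both the group and where it sits on the ring, and the compounds shown cannot separate the two. They also leave open how a nitrile or an amine on that ring would read.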